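Swapping the Amide Aryl Group in a Cytotoxic Series

The source may hold more compounds than are shown below. What is called first, only, known or untested is meant among the compounds shown, and "the series" means these compounds.

Compound 1 `C=CC1=C(C(=O)Nc2ccc(OCC)cc2)C(c2ccc(OC)cc2)OC1`: 17600 nM
Compound 2 `C=CC1=C(C(=O)NCc2ccc(OC)c(OC)c2)C(c2ccc(F)cc2)OC1`: > 100000 nM
Compound 3 `C=CC1=C(C(=O)Nc2ccc(OCC)cc2)C(c2ccc(F)cc2)OC1`: "not active" (no number reported)

Three compounds share one core and were tested in a functional assay on A549 cells (Homo sapiens) for cytotoxicity, read by MTT assay, with a stated time of 24 h; a higher number here means a weaker inhibitor, a lower number a stronger inhibitor. For the measured compounds named here, compound 1 gives 17600 nM in this assay, and it is the only compound with a single number. Compound 2 sits at a limit of this assay, > 100000 nM, so its true value is not known. Compound 3 is recorded as "not active" (no number reported) in this assay, with no number given. Going by the values given here, no pair of these measured compounds differs in just one place, so no measured step is available to lean on; the one piece of supporting evidence is the limit of > 100000 nM in this assay, at which 1 of the 3 values shown sits.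

Compound 4 `C=CC1=C(C(=O)Nc2ccccc2OC)C(c2ccc(OC)cc2)OC1` is not yet measured. It differs from compound 1 by 2-methoxyphenyl in place of 4-ethoxyphenyl on an amide-type nitrogen. Among the compounds with values here, with no measured step to guide the size of this change, the expected shift is modest and toward a weaker inhibitor, giving an estimated step of a 1.7-fold higher number from compound 1 to compound 4 (0.23 log units; within the scatter). Compound 4 is therefore expected to give about 30000 nM in this assay, within a range from 8000 nM to 100000 nM.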

Compound 4, half-maximal inhibitory concentration: > 100000 nM
Compound 4 gave a limit, no number (the forecaster's own chance of this, stated with the estimate: 35%); middle value at least 3.3-fold (0.52 log units) from the limit.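

On an amide-type nitrogen, the aryl group of this series cannot be exchanged freely: in this assay, putting 2-methoxyphenyl in place of 4-ethoxyphenyl gives an at least 5.6-fold higher number from compound 1 to compound 4 (0.75 log units; beyond the scatter). For the compounds shown here, this is the first measured step, and it shows that a swap between two groups of similar size can shift the result beyond the scatter. Compound 4 reached a limit of the assay, so the true size of the step remains unknown, and that limit is now shared by more than one compound in the series: the limit of > 100000 nM in this assay, at which 2 of the 4 values shown sit.

The compounds shown leave open whether the loss comes from the changed ring position or from the shorter ether chain, as both change together in this step. They also leave open how a plain phenyl group, or a phenyl group carrying an amine or a carboxylic acid, would behave on the same nitrogen.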